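This account rests on a few compounds, and the source may have more. Where it says the series, first, only, none or still open, it means among the compounds named here.

Compound 1 `CN(C)CCn1cnnc1-c1cc(Oc2ccc(NC(=O)N/N=C/c3cccc(Br)c3)cc2F)ccn1` was tested in a functional assay on MKN-45 cells (Homo sapiens) for cytotoxicity, read by MTT assay, with a stated time of 72 h (a lower number here means a stronger inhibitor, a higher number a weaker inhibitor), where compound 1 gives 450 nM. Two close relatives differ only in the aromatic ring on the carbon with a double bond to nitrogen. Compound 2 `CN(C)CCn1cnnc1-c1cc(Oc2ccc(NC(=O)N/N=C/c3ccc(F)cc3Cl)cc2F)ccn1` gives 870 nM, and compound 3 `CN(C)CCn1cnnc1-c1cc(Oc2ccc(NC(=O)N/N=C/c3ccc(Cl)cc3)cc2F)ccn1` gives 570 nM. Compound 1 sits at the low end of these three numbers, but none of the gaps is telling: there is a 1.9-fold higher number from compound 1 to compound 2 (0.29 log units; within the scatter), a 1.3-fold higher number from compound 1 to compound 3 (0.10 log units; within the scatter) and a 1.5-fold lower number from compound 2 to compound 3 (0.18 log units; within the scatter).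

Compound 4 `CN(C)CCn1cnnc1-c1cc(Oc2ccc(NC(=O)N/N=C/c3ccc(O)c(F)c3)cc2F)ccn1` changes the same ring again: 3-fluoro-4-hydroxyphenyl in place of 3-bromophenyl on a carbon with a double bond to nitrogen. Within the data shown here, the group that enters carries a hydrogen-bond donor and acceptor, which none of the measured rings do, so no measured step speaks directly to this change. The three swaps that were measured all stayed within the scatter, so a step of similar size, in no particular direction, is expected. The estimate for compound 4 is therefore 600 nM, within 250 nM to 1500 nM. This estimate means a 1.3-fold higher number from compound 1 to compound 4 (0.12 log units; within the scatter) is expected.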

Compound 4, half-maximal inhibitory concentration: 1970 nM
For compound 4 the middle estimate is 3.3-fold (0.52 log units) below the measured one, outside the stated range (above it).
By their numbers in this assay, from the lowest: compounds 1, 3 and 2 (each within the scatter of the next); then compound 4.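

This position tolerates less than the first three rings suggested. In this assay, among these compounds, 3-fluoro-4-hydroxyphenyl is the first ring to shift the number beyond the scatter, making compound 4 the weakest of the four, and the step is clear against each halogen-only ring (a 4.4-fold higher number from compound 1 to compound 4 (0.64 log units; beyond the scatter); a 3.5-fold higher number from compound 3 to compound 4 (0.54 log units; beyond the scatter); a 2.3-fold higher number from compound 2 to compound 4 (0.35 log units; beyond the scatter)). It is also the only ring here with a hydrogen-bond donor and acceptor, though that is a coincidence of structure and nothing shown explains the loss.

With one such compound, the hydroxy group cannot be separated from the fluorine that accompanies it. The compounds shown also leave open whether a methoxy group or an amine on this ring would give a number like that of compound 4 or one closer to those of the halogen-bearing rings.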